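Tolerated Compounds and a Swap of Aromatic Ring

The source may hold more compounds than are shown below. What is called first, only, known or untested is meant among the compounds shown, and "the series" means these compounds.

Compound 1 `Cc1cc(-c2ccccc2)n2nc(C(=O)Nc3sc4c(c3C(=O)O)CCCCC4)nc2n1` gives > 250000 nM as a limit
Compound 2 `Cc1cc(-c2ccccc2)nc2nc(C(=O)Nc3ccsc3C(N)=O)nn12` gives 240000 nM as a number

Both results come from an ADME assay on MDCK cells (Canis lupus familiaris) for cytotoxicity, read by MTT assay, with a stated time of 48 h (a higher number here means that more compound is tolerated, a lower number that less compound is tolerated), and are read as the half-maximal cytotoxic concentration. The entry for compound 1 at > 250000 nM is a limit and not a number. Among the measured compounds shown here, that leaves compound 2, at 240000 nM as the only number available.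

Compound 3 `Cc1cc(-c2ccccc2)nc2nc(C(=O)Nc3ccccc3C(N)=O)nn12` keeps the shared core of compound 2 and differs from it in one place: 2-carbamoylphenyl in place of 2-carbamoylthiophen-3-yl on an amide-type nitrogen. In words, 2-carbamoylphenyl stands in place of 2-carbamoylthiophen-3-yl on an amide-type nitrogen.

For the measured compounds named here, no measured pair shows what such an exchange does, so the expectation rests on compound 2 alone. Compound 2 has little room to climb because the limit of > 250000 nM in this assay, at which 1 of the 2 values shown sits, and a reading for compound 3 may also end at that limit. No change beyond the usual scatter is expected, and the estimated move is a 1.2-fold lower number from compound 2 to compound 3 (0.08 log units; within the scatter) in this direction. For compound 3 the expected value in this assay is 200000 nM with 100000 nM to 250000 nM as the estimated range.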

Compound 3, half-maximal cytotoxic concentration: > 250000 nM
Compound 3: no number, only a limit; the forecaster's own chance of this, stated with the estimate: 35%; at least 1.2-fold (0.09 log units) between middle value and limit.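

Placing 2-carbamoylphenyl in place of 2-carbamoylthiophen-3-yl on an amide-type nitrogen gives the first step seen at this position, an at least 1.0-fold higher number from compound 2 to compound 3 (0.01 log units; that floor lies within the scatter). In this assay compound 3 gives > 250000 nM, and this entry is a limit and not a number. At this position, then, one six-membered aromatic ring of carbon only takes the place of one five-membered aromatic ring with a hetero atom without any lower number appearing in this assay, yet the full size of the step cannot be read because the reading ends at a limit: the limit of > 250000 nM in this assay, at which 2 of the 3 values shown sit.

The compounds shown leave open whether any group on this amide-type nitrogen would give a number clearly lower than these, since neither ring tells how far the tolerated concentration can fall at this position. They also leave open whether an amine or a nitrile in place of the carbamoyl group on the phenyl ring would keep the reading at the limit or bring it down to a measurable number.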